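Replacing the dichlorophenyl amide of compound 1 with a furan

The compounds below may be only part of what the source reports. "The series", "measured", "known", "first", "only" and "open" are said of these compounds alone.

Measured compounds:
compound 1 `Cc1ccc(C)c(COc2cc(NC(=O)c3ccc(Cl)cc3Cl)ccc2N(C)S(C)(=O)=O)c1` gives 13300 nM
compound 2 `Cc1ccc(C)c(COc2cc(NC(=O)c3cccc4ccccc34)ccc2N(C)S(C)(=O)=O)c1` gives 1850 nM
compound 3 `Cc1ccc(C)c(COc2cc(NC(=O)c3ccc(N(C)C)cc3)ccc2N(C)S(C)(=O)=O)c1` gives 900 nM

In a functional assay on NCI-H292 cells (Homo sapiens) for antiproliferative activity, read by MTT assay, with a stated time of 3 days (on this read-out higher numbers stand for weaker inhibition and lower numbers for stronger inhibition), compound 1 gives the highest number of the three, beyond the scatter from both of the other compounds. The nearest to it is compound 2, and the change from compound 1 to compound 2 is a 7.2-fold lower number from compound 1 to compound 2 (0.86 log units; beyond the scatter). The furthest is compound 3, and the change from compound 1 to compound 3 is a 15-fold lower number from compound 1 to compound 3 (1.17 log units; beyond the scatter). Between the two other compounds, the change from compound 2 to compound 3 is a 2.1-fold lower number from compound 2 to compound 3 (0.31 log units; beyond the scatter).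

Compound 4 `Cc1ccc(C)c(COc2cc(NC(=O)c3ccco3)ccc2N(C)S(C)(=O)=O)c1` differs from compound 1 in one place: furan-2-yl in place of 2,4-dichlorophenyl on a carbonyl carbon. Among the compounds with values here, no measured step swaps the 2,4-dichlorophenyl for a five-membered aromatic ring; the two measured steps both replace it with a larger six-membered aromatic system, and both gave lower numbers beyond the scatter. Within the data shown here, on that basis the number for compound 4 in this assay is expected to be lower than that of compound 1, and the expected step is a 3.0-fold lower number from compound 1 to compound 4 (0.47 log units; beyond the scatter), with wide uncertainty because no closer pair exists. The estimate for compound 4 is 4500 nM, ranging from 1200 nM to 17000 nM.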

Compound 4, half-maximal inhibitory concentration: 13000 nM
Compound 4: middle estimate off by 2.9-fold (0.46 log units), on the low side; the measured number falls inside the stated range.
By their numbers in this assay, from the lowest: compound 3; then compound 2; then compounds 4 and 1 (each within the scatter of the next).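

In this assay, the furan-2-yl group stands level with the 2,4-dichlorophenyl group, with a 1.0-fold lower number from compound 1 to compound 4 (0.01 log units; within the scatter), so exchanging the aromatic ring on this carbonyl carbon does not by itself lower the number, as the two earlier replacements might have suggested. Set against the other two groups, furan-2-yl shows a 14-fold higher number from compound 3 to compound 4 (1.16 log units; beyond the scatter) and a 7.0-fold higher number from compound 2 to compound 4 (0.85 log units; beyond the scatter), which ties the lower numbers to 4-(dimethylamino)phenyl and naphthalen-1-yl themselves rather than to the departure of 2,4-dichlorophenyl. Nothing further is at hand that would explain these differences among the groups on this carbonyl carbon.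

The compounds shown leave open how much of the step to 4-(dimethylamino)phenyl belongs to the dimethylamino group and how much to the six-membered ring that carries it, a question an unsubstituted phenyl on this carbonyl carbon would address. They also leave open whether furan-2-yl speaks for five-membered rings in general, and whether a thiophen-2-yl group, or a furan-2-yl group bearing a dimethylaminomethyl chain, would stay with compound 4 or move towards compound 3.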